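The source may hold more compounds than are shown below. What is called first, only, known or untested is meant among the compounds shown, and "the series" means these compounds.

Of the compounds shown here, three of one series have been measured in a functional assay on MCF7 cells (Homo sapiens) for cytotoxicity, read by CCK-8 assay, with a stated time of 48 h; on this read-out higher numbers stand for weaker inhibition and lower numbers for stronger inhibition. Compound 1 `Cc1cc(NS(=O)(=O)c2ccc(/N=C/c3c(Cl)c4cc(C(C)(C)C)cc(C(C)(C)C)c4oc3=O)cc2)no1` gives 64 nM in this assay, and compound 2 `Cc1ccnc(NS(=O)(=O)c2ccc(/N=C/c3c(Cl)c4cc(C(C)(C)C)cc(C(C)(C)C)c4oc3=O)cc2)n1` gives 32 nM. Between them lies a single change, (4-methylpyrimidin-2-yl in place of 5-methyl-1,2-oxazol-3-yl on a sulfonamide nitrogen), and it made a 2.0-fold lower number from compound 1 to compound 2 (0.30 log units; within the scatter). Compound 3 `Cc1ccc2oc(=O)c(/C=N/c3ccc(S(=O)(=O)Nc4cc(C)on4)cc3)c(Cl)c2c1` rests on another core; how the two cores differ is not broken down here. In this assay compound 3 gives 16 nM, a number whose gap to compound 2 stays within the scatter while its gap to compound 1 lies beyond it. Compound 4 `Cc1ccc2oc(=O)c(/C=N/c3ccc(S(=O)(=O)Nc4nccc(C)n4)cc3)c(Cl)c2c1` carries the same change set on the core of compound 3, namely (4-methylpyrimidin-2-yl in place of 5-methyl-1,2-oxazol-3-yl on a sulfonamide nitrogen), at the same place, a sulfonamide nitrogen whose other neighbour is a sulfonyl sulfur. The step of a 1.6-fold lower number from compound 3 to compound 4 (0.20 log units; within the scatter) is expected to be of the same modest kind, because the earlier step made a 2.0-fold lower number from compound 1 to compound 2 (0.30 log units; within the scatter) and that lay within the scatter. Compound 4 is therefore estimated at 10 nM in this assay, with a likely range from 4 nM to 25 nM.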

Compound 4, half-maximal inhibitory concentration: 61 nM
Compound 4: the middle estimate sits 6.1-fold (0.79 log units) below what was measured, and the stated range ends below it.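

In this assay the exchange of 5-methyl-1,2-oxazol-3-yl for 4-methylpyrimidin-2-yl on the core of compound 3 gave a 3.8-fold higher number from compound 3 to compound 4 (0.58 log units; beyond the scatter) and so did not repeat what had been seen for the same change on the core of compound 1. Set side by side, the two steps differ by more than repeated measurements would account for: the same change on two cores in this assay, a 2.0-fold lower number (0.30 log units; within the scatter) from compound 1 to compound 2 and a 3.8-fold higher number (0.58 log units; beyond the scatter) from compound 3 to compound 4, 7.6-fold (0.88 log units) apart, beyond the scatter of two such steps. This shows that, for these two cores, the outcome of this change on a sulfonamide nitrogen cannot be carried from one core to the other, but it does not show which feature of the cores is responsible, and one pair on each core gives no rule for any further core.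

From the compounds shown here alone, it remains open how a third core would respond to the same change. Going by these compounds, it is also open whether another group on the sulfonamide nitrogen, such as a thiazole or a pyridine ring, would show the same dependence on the core.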